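Ring stereocentre inversion in the nitrate-ester dihydropyridine pair

The compounds below may be only part of what the source reports. "The series", "measured", "known", "first", "only" and "open" are said of these compounds alone.

Working notes on the series. Compound 1 `CC1=C(C(=O)O[C@@H](C)CO[N+](=O)[O-])[C@H](c2cccc3nonc23)C([N+](=O)[O-])=C(C)C1` gives 9430 nM in a functional assay (ileum) for antagonist activity, with Cavia porcellus as the target; a lower number here means a stronger inhibitor, a higher number a weaker inhibitor. Compound 2 `CC1=C(C(=O)O[C@H](C)CO[N+](=O)[O-])[C@H](c2cccc3nonc23)C([N+](=O)[O-])=C(C)C1` gives 36500 nM in this assay, the highest of the two numbers; its nearest neighbour is compound 1, and the step of a 3.9-fold higher number from compound 1 to compound 2 (0.59 log units; beyond the scatter) rests only on (the fact that compounds 1 and 2 differ only in the configuration as drawn). Compound 3 `CC1=C(C(=O)O[C@H](C)CO[N+](=O)[O-])[C@@H](c2cccc3nonc23)C([N+](=O)[O-])=C(C)C1` has not been measured in this assay. It differs from compound 2 as follows: the two compounds have the same atoms and bonds and differ only in configuration as drawn: 1 of 2 stereo elements differ; a stereocentre at a saturated ring carbon is drawn S in compound 2 and R in compound 3. Going by the values given here, the only measured step, a 3.9-fold higher number from compound 1 to compound 2 (0.59 log units; beyond the scatter), concerns the chain stereocentre, not the ring stereocentre, so it gives the scale of a configurational change but not its direction here. A step of comparable size is expected for a 2.4-fold lower number from compound 2 to compound 3 (0.39 log units; beyond the scatter), with the direction open. Compound 3 is therefore estimated at 15000 nM in this assay, within a range of 2500 nM to 90000 nM.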

Compound 3, half-maximal inhibitory concentration: 59.6 nM
For compound 3 the middle estimate is 250-fold (2.40 log units) above the measured one; the measured number lies below the stated range.
By their numbers in this assay, from the lowest: compound 3; then compound 1; then compound 2.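

In this assay the ring stereocentre carries far more weight than the chain stereocentre: with the chain centre drawn R, changing the ring centre from S to R gives the large step (a 610-fold lower number from compound 2 to compound 3 (2.79 log units; beyond the scatter)), against the modest chain step (a 3.9-fold higher number from compound 1 to compound 2 (0.59 log units; beyond the scatter)). The mirror-image pair is also widely separated (a 160-fold lower number from compound 1 to compound 3 (2.20 log units; beyond the scatter)), so the two enantiomers are far apart in this assay. The large step comes with no change in atoms or bonds: the fact that compounds 2 and 3 differ only in the configuration as drawn.

The effect of the chain stereocentre with the ring centre drawn R remains open, as the only chain step shown has the ring centre drawn S. Also open is whether the ring configuration keeps this weight with a longer chain on the ester or with a carboxylic acid in place of the ester.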